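Dichlorophenyl in place of methoxyphenyl at the limit

The source may hold more compounds than are shown below. What is called first, only, known or untested is meant among the compounds shown, and "the series" means these compounds.

Measured compounds in a toxicity assay on HEK-293T cells (Homo sapiens) for inhibition, read by MTT assay, with a stated time of 24 h; a higher number here means that more compound is tolerated, a lower number that less compound is tolerated:
Compound 1 `O=c1oc2ccccc2c(N2CCN(c3ccccc3)CC2)c1CO` gives > 50000 nM (a limit)
Compound 2 `O=c1oc2ccccc2c(N2CCN(c3ccccc3F)CC2)c1CO` gives > 50000 nM (a limit)
Compound 3 `COc1ccccc1N1CCN(c2c(CO)c(=O)oc3ccccc23)CC1` gives > 50000 nM (a limit)

Compound 3 has no exact number and stands at the limit of > 50000 nM in this assay, at which 3 of the 3 values shown sit. Compound 4 `O=c1oc2ccccc2c(N2CCN(c3ccc(Cl)c(Cl)c3)CC2)c1CO` carries 3,4-dichlorophenyl in place of 2-methoxyphenyl on an amine nitrogen in a ring. Within the data shown here, three measured steps bear on this change: a step that the two limits leave unreadable from compound 1 to compound 2, a step that the two limits leave unreadable from compound 1 to compound 3 and a step that the two limits leave unreadable from compound 2 to compound 3. None of them gives a size, and the new group has not been measured in this series. In this assay only a small shift toward lower tolerated concentrations is expected, and possibly none beyond the scatter. The expected change is an at least 1.1-fold lower number from compound 3 to compound 4 (0.04 log units; that floor lies within the scatter) as an estimate. The estimate for compound 4 is 45000 nM (expected range 15000 nM to 100000 nM) and it may well prove to be another limit.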

Compound 4, half-maximal cytotoxic concentration: > 50000 nM
Compound 4: no number, only a limit; the forecaster's own chance of this, stated with the estimate: 70%; middle value at least 1.1-fold (0.04 log units) from the limit.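

In this assay, among these compounds, compound 4 gives only a limit, as do compounds 1, 2 and 3, so no step among them can be read: the limit of > 50000 nM in this assay, at which 4 of the 4 values shown sit. As far as these compounds go, whether the groups on the ring nitrogen make any difference to the tolerated concentration remains open.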